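The source may report more compounds than this note shows. Statements on the series, on what has been measured and on what is new or still open speak of the compounds shown alone.

Measured so far:
compound 1 `CCOC(=O)c1sc(-c2ccccn2)nc1N1CCC(NCc2ccc(OCc3ccccc3)cc2)CC1` — 12.8%
compound 2 `CCOC(=O)c1sc(-c2ccncc2)nc1N1CCC(NCc2ccc(OC)cc2)CC1` — 16.1%

In an ADME assay on RAW264.7 cells (Mus musculus) for cytotoxicity, read by MTT assay, with a stated time of 72 h, tested at 50 uM (on this read-out lower numbers stand for less inhibition and higher numbers for more inhibition at the one concentration tested (going by the name of the read-out)), compound 1 gives 12.8% and compound 2 gives 16.1%; these two numbers lie within the usual scatter of each other, so compound 2 stands alongside compound 1 rather than apart from it. Among the compounds with values here, the two compounds differ in more than one place, and no single step between them can be read off. Compound 3 `CCOC(=O)c1sc(-c2ccncc2)nc1N1CCC(NCc2ccc(OCc3ccccc3)cc2)CC1` is not yet measured. It differs from compound 2 in one place: phenyl in place of hydrogen on a saturated chain carbon bound to an oxygen on an aromatic ring. Because compound 1 already carries the benzyloxy group and gives 12.8%, the change is expected to move the number little. Compound 3 is therefore estimated at 15%, with a range from 5% to 27%. The expected step of a number 1.1 percentage points lower from compound 2 to compound 3 (within the scatter) is judged to stay within the scatter.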

Compound 3, a percentage reported as inhibition, at one concentration (the size of the read-out at that concentration, not a potency): 8.04%
Beside the measured number, compound 3's estimate is 7 percentage points above it, and the stated range covers the measured number.
By their numbers in this assay, from the lowest: compounds 3, 1 and 2 (each within the scatter of the next).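

In this assay, methoxy to benzyloxy gives a number 8.1 percentage points lower from compound 2 to compound 3 (within the scatter), so phenyl on this saturated chain carbon bound to an oxygen on an aromatic ring leaves the reading within the scatter. Within the data shown here, with benzyloxy in place in both compounds, pyridin-4-yl in place of pyridin-2-yl on an aromatic carbon gives a number 4.8 percentage points lower from compound 1 to compound 3 (within the scatter), which isolates that change for the first time and also stays within the scatter. Nothing measured bears on the cause of either step. The compounds shown leave open how an amine or a carboxylic acid on that chain carbon would read.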